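The source may hold more compounds than are shown below. What is called first, only, known or untested is meant among the compounds shown, and "the series" means these compounds.

In a functional assay on HepG2 cells (Homo sapiens) for inhibition, read by MTT assay, with a stated time of 48 h (a lower number here means a stronger inhibitor, a higher number a weaker inhibitor), compound 1 `COc1cc(/C=N/Nc2nc(-c3ccc(Br)cc3)cs2)cc(Br)c1OC` gives 64600 nM. Compound 2 `COc1cc(/C=N/Nc2nc(-c3ccc(C(F)(F)F)cc3)cs2)c(Br)c(Br)c1OC` returns only a limit in this assay, > 100000 nM, so where it stands is bounded but not fixed; this matches (the limit of > 100000 nM in this assay, at which 1 of the 2 values shown sits). Compound 3 `COc1cc(/C=N/Nc2nc(-c3ccc(C(F)(F)F)cc3)cs2)cc(Br)c1OC` arises from compound 2 through (hydrogen in place of bromo on an aromatic carbon), hydrogen in place of bromo on an aromatic carbon. With compound 2 known only as a limit, the step from compound 2 to compound 3 is expected to be an at least 1.4-fold lower number from compound 2 to compound 3 (0.15 log units; that floor lies within the scatter), a change that need not exceed the usual scatter. Compound 3 is therefore estimated at 70000 nM in this assay, between 25000 nM and 150000 nM.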

Compound 3, half-maximal inhibitory concentration: 31200 nM
Compound 3: middle estimate off by 2.2-fold (0.35 log units), on the high side, within the range that was stated.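

In this assay, hydrogen in place of the bromo group para to a methoxy group gives an at least 3.2-fold lower number from compound 2 to compound 3 (0.50 log units; beyond the scatter), so removing this bromo group moves the number beyond the scatter. Compound 2 is known only as a limit, so that step is a floor: the limit of > 100000 nM in this assay, at which 1 of the 3 values shown sits. At the other site of change, trifluoromethyl in place of bromo on an aromatic carbon gives a 2.1-fold lower number from compound 1 to compound 3 (0.32 log units; beyond the scatter), a modest step. The compounds shown leave open how a chloro group, an amine or a methyl group at the position para to a methoxy group would read in this assay.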